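Acetylating a Ring Hydroxyl in a Weakly Cytotoxic Series

The source may report more compounds than this note shows. Statements on the series, on what has been measured and on what is new or still open speak of the compounds shown alone.

Compound 1 `CC(=O)O[C@@H]1OC(=O)[C@@](Cc2ccccc2)(C(C)=O)[C@@H]1C` and compound 2 `CC(=O)O[C@@H]1OC(=O)[C@@](O)(C(C)=O)[C@@H]1C` share one core and differ at a single saturated ring carbon, where compound 1 carries a benzyl group and compound 2 a hydroxy group. In a functional assay on MCF7 cells (Homo sapiens) for cytotoxicity, read by MTT assay (on this read-out lower numbers stand for stronger inhibition and higher numbers for weaker inhibition), compound 1 gives 51000 nM. For compound 2 this assay reports only a limit, > 50000 nM. The step that the limit leaves unreadable from compound 1 to compound 2 cannot be sized because the limit of > 50000 nM in this assay, at which 1 of the 2 values shown sits, covers compound 2, so compound 2 stands at the edge of what this assay can read, a weak inhibitor at best.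

Compound 3 `CC(=O)O[C@@H]1OC(=O)[C@@](OC(C)=O)(C(C)=O)[C@@H]1C` carries the change (acetyl in place of hydrogen on an oxygen on a saturated carbon), that is, hydroxy becomes acetoxy on the oxygen attached to the saturated ring carbon. Among the compounds with values here, no measured step involves adding an acetyl group to an oxygen, and the only step measured so far is unreadable. The expectation for compound 3 therefore rests on the two values alone, both of which sit at or close to the same limit. The expected step of a number no higher from compound 2 to compound 3 (the limit leaves the size open) is none beyond the scatter. For compound 3 the expected value in this assay is 50000 nM, with a range from 15000 nM to 150000 nM.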

Compound 3, half-maximal inhibitory concentration: > 50000 nM
Compound 3: no number, only a limit (the forecaster's own chance of this, stated with the estimate: 60%); the middle value sits exactly at the limit.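

Neither step to compound 3, from compound 1 or from compound 2, can be read, because the values of compound 2 and compound 3 are limits rather than numbers: the limit of > 50000 nM in this assay, at which 2 of the 3 values shown sit.

The compounds shown leave open how compound 2 and compound 3 truly compare with compound 1, and whether hydroxy and acetoxy differ at all in this assay.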